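Thiophene, furan and pyridine on the side-chain methylene

A few compounds are considered here, and "the series" means these few. Any claim that something is new, unique, unknown or untested is made for them only; others in the source may bear on it.

Measured compounds in an assay on CHO cells for displacement of a labelled ligand from adenosine receptor A1 (Homo sapiens), read by scintillation counting, with a stated time of 90 min; on this read-out higher numbers stand for weaker inhibition and lower numbers for stronger inhibition:
compound 1 `Nc1nc(NCc2cccs2)nc2sc(-c3ccco3)nc12`, 12.5 nM
compound 2 `Nc1nc(NCc2ccco2)nc2sc(-c3ccco3)nc12`, 38 nM
compound 3 `Nc1nc(NCc2ccccn2)nc2sc(-c3ccco3)nc12`, 28 nM

Compound 3 holds the second highest number of the three; the gap to compound 2 is within the scatter, while compound 1 lies lower by a 2.2-fold higher number from compound 1 to compound 3 (0.35 log units; beyond the scatter). Compound 4 `Nc1nc(NCc2ccsc2)nc2sc(-c3ccco3)nc12` differs from compound 3 by thiophen-3-yl in place of pyridin-2-yl on a saturated chain carbon bound to a nitrogen on an aromatic ring. The step that bears on this is the one from thiophen-2-yl to pyridin-2-yl, a 2.2-fold higher number from compound 1 to compound 3 (0.35 log units; beyond the scatter), read in reverse; the furan step, a 3.0-fold higher number from compound 1 to compound 2 (0.48 log units; beyond the scatter), points the same way. A thiophen-3-yl ring is not the same as thiophen-2-yl, so only a modest lowering is expected, a 1.6-fold lower number from compound 3 to compound 4 (0.19 log units; within the scatter) in this assay. Compound 4 is therefore estimated at 18 nM, with a range of 8 nM to 40 nM.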

Compound 4, inhibition constant: 8.12 nM
Compound 4: middle estimate off by 2.2-fold (0.35 log units), on the high side; low and high end bracket the measured number.
By their numbers in this assay, from the lowest: compounds 4 and 1 (each within the scatter of the next); then compounds 3 and 2 (each within the scatter of the next).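

In this assay, thiophen-3-yl and thiophen-2-yl on the side-chain carbon cannot be told apart (a 1.5-fold lower number from compound 1 to compound 4 (0.19 log units; within the scatter)). Both thiophene isomers now sit apart from the other two rings, with thiophen-3-yl giving lower numbers than pyridin-2-yl (a 3.4-fold lower number from compound 3 to compound 4 (0.54 log units; beyond the scatter)) and furan-2-yl (a 4.7-fold lower number from compound 2 to compound 4 (0.67 log units; beyond the scatter)). Nothing at hand accounts for this ring preference.

Open, on these data alone, is whether a sulfur-containing ring is needed at all, which a plain phenyl or cyclohexyl ring on the same carbon would test. Also open, as far as these compounds go, is how a longer chain carrying the thiophene would read.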